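Replacing an Aminohydroxyimidazole by a Triazole on the Ether Side Chain

The source may report more compounds than this note shows. Statements on the series, on what has been measured and on what is new or still open speak of the compounds shown alone.

Compound 3 `CCO/C(O)=C1\C(COCCn2cc(N)nc2O)=NC(C)=C(C(=O)OC)C1c1ccccc1Cl` gives the highest number of the three measured compounds in a functional assay (aorta) with Rattus norvegicus as the target (a lower number here means a stronger inhibitor, a higher number a weaker inhibitor), at 31.6 nM. Compound 2 `CCO/C(O)=C1\C(COCCn2ccnc2C)=NC(C)=C(C(=O)OC)C1c1ccccc1Cl` gives 2.51 nM, and compound 1 `CCO/C(O)=C1\C(COCCn2ccnn2)=NC(C)=C(C(=O)OC)C1c1cccc(Cl)c1Cl` gives 5.01 nM. The step from compound 3 to compound 4 `CCO/C(O)=C1\C(COCCn2ccnn2)=NC(C)=C(C(=O)OC)C1c1ccccc1Cl` is 1H-1,2,3-triazol-1-yl in place of 4-amino-2-hydroxy-1H-imidazol-1-yl on a saturated chain carbon, two bonds along the chain from an oxygen on a saturated carbon. Going by the values given here, the one measured step that bears on it is a 13-fold higher number from compound 2 to compound 3 (1.10 log units; beyond the scatter), which shows that swapping the 4-amino-2-hydroxy-1H-imidazol-1-yl group in for another small azole brought a large loss in this assay; read backwards, removing it should recover much of that. Compound 1, which carries the same 1H-1,2,3-triazol-1-yl group on a different aryl ring, also sits far below compound 3. Compound 4 is therefore expected to give a markedly lower number, with an estimated step of a 7.9-fold lower number from compound 3 to compound 4 (0.90 log units; beyond the scatter). For compound 4 the estimated value in this assay is 4 nM, with a range from 1.5 nM to 12 nM.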

Compound 4, half-maximal inhibitory concentration: 15.9 nM
Compound 4: middle estimate off by 4.0-fold (0.60 log units), on the low side; the measured number lies above the stated range.
By their numbers in this assay, from the lowest: compounds 2 and 1 (each within the scatter of the next); then compounds 4 and 3 (each within the scatter of the next).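

In this assay, the 1H-1,2,3-triazol-1-yl group does not match the 2-methyl-1H-imidazol-1-yl group on this saturated chain carbon: a 6.3-fold higher number from compound 2 to compound 4 (0.80 log units; beyond the scatter), which is beyond the scatter, while a 2.0-fold lower number from compound 3 to compound 4 (0.30 log units; within the scatter) stays within it. The large loss seen earlier is therefore not tied to the 4-amino-2-hydroxy-1H-imidazol-1-yl group alone, and at this place the 2-methyl-1H-imidazol-1-yl group stands apart from both other rings. The triazole also does not account for the low number of compound 1 by itself, since the change of chloro to hydrogen on an aromatic carbon gives a 3.2-fold higher number from compound 1 to compound 4 (0.50 log units; beyond the scatter), and no independent evidence bears on any of these differences.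

Going by these compounds, it remains open whether that chloro would bring a similar step alongside the 2-methyl-1H-imidazol-1-yl group. Also open, on these data alone, is whether the methyl matters, which a plain 1H-imidazol-1-yl group or an open-chain amine on the same carbon could test.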